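Cytotoxicity in Vero Cells Across a Benzimidazole-Type Series

A few compounds are considered here, and "the series" means these few. Any claim that something is new, unique, unknown or untested is made for them only; others in the source may bear on it.

Compound 1 `CC(=O)c1ccc2[nH]c(-c3ccc(Cl)cc3)nc2c1`: > 100000 nM
Compound 2 `CC(=O)c1ccc2c(c1)nc(-c1ccc(Cl)cc1)n2C1CCCCC1`: > 100000 nM
Compound 3 `C/C(=N\NC(N)=O)c1ccc2c(c1)nc(-c1ccoc1)n2C1CCCCC1`: "not determined" (no result reported)

In an ADME assay on Vero cells (Chlorocebus sabaeus) for cytotoxicity, read by MTT assay, with a stated time of 96 h (a higher number here means that more compound is tolerated, a lower number that less compound is tolerated), compound 1 reaches only the limit of the assay, > 100000 nM. Compound 2 likewise sits at the limit, > 100000 nM. The change from compound 2 to compound 1 is hydrogen in place of cyclohexyl on an aromatic nitrogen, and the step is a step that the two limits leave unreadable from compound 2 to compound 1; both values rest on (the limit of > 100000 nM in this assay, at which 2 of the 3 values shown sit). Compound 3 has no result in this assay, and the difference between its core and that of compound 2 is not broken down here. Compound 4 `C/C(=N\NC(N)=O)c1ccc2[nH]c(-c3ccoc3)nc2c1` differs from compound 3 by hydrogen in place of cyclohexyl on an aromatic nitrogen, the same kind of change, though here the ring nitrogen sits next to the ring atom that bears a furan-3-yl group rather than a 4-chlorophenyl group. Compound 4 is expected to give 150000 nM, most likely again as a limit, given (the limit of > 100000 nM in this assay, at which 2 of the 3 values shown sit).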

Compound 4, half-maximal cytotoxic concentration: > 100000 nM
Compound 4 ended at the assay's limit; the forecaster's own chance of this, stated with the estimate: 80%; the middle value lies beyond the limit too.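

No new step can be read between compound 3 and compound 4. In this assay compound 4 sits at a limit of the assay, > 100000 nM. The compounds shown leave open whether swapping cyclohexyl for hydrogen changes tolerance at all.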